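Biaryl tail variation and mouse liver microsomal stability

This account rests on a few compounds, and the source may have more. Where it says the series, first, only, none or still open, it means among the compounds named here.

Measured so far:
Compound 1 `O=[N+]([O-])c1cn2c(n1)OC[C@@H](OCc1ccc(-c3ccc(CNc4ccccc4)cc3)cc1)C2`: 52%
Compound 2 `N#Cc1ccc(-c2ccc(CO[C@@H]3COc4nc([N+](=O)[O-])cn4C3)cc2)cc1`: 58%

For the measured compounds named here, in an ADME assay on microsomes from liver (Mus musculus, strain CD1) for metabolic stability, read by LC-MS, with a stated time of 1 h (on this read-out lower numbers stand for a less stable compound and higher numbers for a more stable compound), compound 2 gives 58%, and compound 1 gives 52%; the only measured step, a number 6 percentage points higher from compound 1 to compound 2 (within the scatter), lies within the scatter, so the two numbers are not separated.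

Compound 3 `COc1cccc(F)c1-c1ccc(CO[C@@H]2COc3nc([N+](=O)[O-])cn3C2)cc1` differs from compound 2 by 2-fluoro-6-methoxyphenyl in place of 4-cyanophenyl on an aromatic carbon. Going by the values given here, the one step on record, a number 6 percentage points higher from compound 1 to compound 2 (within the scatter), swaps a group on the same aromatic carbon and stayed within the scatter, so it bears only loosely on this larger replacement and suggests no shift beyond the scatter. For compound 3 the expected step in this assay is a number 3 percentage points lower from compound 2 to compound 3 (within the scatter), giving an estimate of 55% with a range from 35% to 75%.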

Compound 3, percent of the compound remaining: 0%
The estimate for compound 3 lay 55 percentage points above the measured number, outside the stated range (below it).
By their numbers in this assay, from the lowest: compound 3; then compounds 1 and 2 (each within the scatter of the next).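

In this assay, this aromatic carbon proves sensitive to what it carries: 2-fluoro-6-methoxyphenyl in place of 4-cyanophenyl gives a number 58 percentage points lower from compound 2 to compound 3 (beyond the scatter). The other step on record, a number 6 percentage points higher from compound 1 to compound 2 (within the scatter), did not show such sensitivity. No available evidence bears on the reason for this drop.

As far as these compounds go, the fluorine and the methoxy group enter together, so their separate contributions remain open. From the compounds shown here alone, it is also open whether a phenyl ring carrying only one of them, or a pyridine ring, would stay close to compound 2.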